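A few compounds are considered here, and "the series" means these few. Any claim that something is new, unique, unknown or untested is made for them only; others in the source may bear on it.

Measured so far in an assay on brain (strain C57BL6) for displacement of a labelled ligand from AP2-associated protein kinase 1 (Mus musculus), read by scintillation counting, with a stated time of 1 h; a higher number here means a weaker inhibitor, a lower number a stronger inhibitor: compound 1 `CC(=O)Nc1cc(-c2ccc(OC[C@@H](N)CC(C)C)c(C)c2)ccn1` gives 0.08 nM; compound 2 `COC(=O)Nc1cc(-c2ccc(OC[C@@](C)(N)CC(C)C)nc2)ccn1` gives 4.9 nM; compound 3 `CC(=O)Nc1cc(-c2ccc(OC[C@@H](N)CC(C)C)cc2)ccn1` gives 0.9 nM.

Compound 1 and compound 3 differ by methyl in place of hydrogen on an aromatic carbon, and this gave an 11-fold lower number from compound 3 to compound 1 (1.05 log units; beyond the scatter). Compound 4 `COC(=O)Nc1cc(-c2cnc(OC[C@@](C)(N)CC(C)C)cc2C)ccn1` is not yet measured; it differs from compound 2 by methyl in place of hydrogen on an aromatic carbon. The difference between the cores of compound 2 and compound 3 is not broken down here. The two methyl additions are the same kind of change, not the same: in compound 1 the methyl sits on a ring of carbon only, ortho to the (2-amino-4-methylpentyl)oxy group and meta to a large group, while in compound 4 it sits on a ring with one nitrogen, ortho to a large group, meta to the (2-amino-2,4-dimethylpentyl)oxy group and opposite the ring nitrogen. The surroundings of the place thus differ, and a smaller gain than the earlier one is taken as the more cautious reading. Compound 4 is therefore expected to improve on compound 2 by a step of a 3.1-fold lower number from compound 2 to compound 4 (0.49 log units; beyond the scatter) in this assay, expected to be smaller than an 11-fold lower number from compound 3 to compound 1 (1.05 log units; beyond the scatter). The estimate for compound 4 is 1.6 nM, expected between 0.5 nM and 6 nM.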

Compound 4, inhibition constant: 41 nM
For compound 4 the middle estimate is 26-fold (1.41 log units) below the measured one; the measured number lies above the stated range.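

In this assay, methyl in place of hydrogen on an aromatic carbon gave an 8.4-fold higher number from compound 2 to compound 4 (0.92 log units; beyond the scatter), so on this core the change went the opposite way from the earlier pair: the same change on two cores in this assay, an 11-fold lower number (1.05 log units; beyond the scatter) from compound 3 to compound 1 and an 8.4-fold higher number (0.92 log units; beyond the scatter) from compound 2 to compound 4, 94-fold (1.97 log units) apart, beyond the scatter of two such steps The gain seen on one core therefore cannot be assumed on another in this series, not even in direction. Among the compounds shown here, it does not show which of the differences between the cores reverses the step, since the two pairs differ in the ring, in the chain and in the place of the methyl, and each core offers only one pair.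

As far as these compounds go, whether fluorine or ethyl in that same place on the core of compound 2 would follow methyl remains open. So does the outcome of the same methyl on a core differing from the core of compound 3 in one place only.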